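This account rests on a few compounds, and the source may have more. Where it says the series, first, only, none or still open, it means among the compounds named here.

Measured in a functional assay on MDA-MB-468 cells (Homo sapiens) for inhibition, read by MTT assay; on this read-out higher numbers stand for weaker inhibition of growth and lower numbers for stronger inhibition of growth:
- compound 1 `CC1=C(/C=C/C(C)=C/C=C/C(C)=C\C(=O)Nc2ccccc2)C(C)(C)CCC1n1ccnc1`: 2540 nM
- compound 2 `CC1=C(/C=C/C(C)=C/C=C/C(C)=C\C(=O)Nc2ccc(O)cc2)C(C)(C)CCC1n1ccnc1`: 6830 nM
- compound 3 `CC1=C(/C=C/C(C)=C/C=C/C(C)=C\C(=O)NCc2ccc(O)cc2)C(C)(C)CCC1n1ccnc1`: 2700 nM

In this set, compound 3 cannot be separated from compound 1, as a 1.1-fold higher number from compound 1 to compound 3 (0.03 log units; within the scatter) shows. It does lie clearly below compound 2, with a 2.5-fold lower number from compound 2 to compound 3 (0.40 log units; beyond the scatter).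

Compound 4 `CC1=C(/C=C/C(C)=C/C=C/C(C)=C\C(=O)NCc2ccccc2)C(C)(C)CCC1n1ccnc1` has hydrogen in place of hydroxy on an aromatic carbon, para to a large group, compared with compound 3: hydrogen in place of hydroxy on an aromatic carbon.

The closest evidence is a 2.7-fold higher number from compound 1 to compound 2 (0.43 log units; beyond the scatter), where hydroxy enters at the same place on a phenyl amide. Run backwards, that modest step points to a lower number on removing hydroxy. However, it is a single step, and it comes from a compound without the benzyl link, so it may carry over only in part. The expected change is therefore a lower number, possibly no larger than the scatter. The estimated step is a 1.8-fold lower number from compound 3 to compound 4 (0.26 log units; within the scatter). For compound 4 the estimated value is 1500 nM, with an expected range of 800 nM to 3000 nM.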

Compound 4, concentration for 50% growth inhibition: 7240 nM
Estimate against measurement, compound 4: 4.8-fold (0.68 log units) below; the whole stated range lies below it.
By their numbers in this assay, from the lowest: compounds 1 and 3 (each within the scatter of the next); then compounds 2 and 4 (each within the scatter of the next).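

On the benzyl amide the hydroxy goes with the lower number, not the higher one: removing it gives a 2.7-fold higher number from compound 3 to compound 4 (0.43 log units; beyond the scatter). Without any hydroxy, benzyl in place of phenyl on the amide nitrogen gives a 2.9-fold higher number from compound 1 to compound 4 (0.45 log units; beyond the scatter), while a 1.1-fold higher number from compound 2 to compound 4 (0.03 log units; within the scatter) leaves those two compounds inseparable. The same change at this position therefore runs in opposite senses on the phenyl and benzyl amides, and no single effect of the hydroxy holds across both: the same change on two cores in this assay, a 2.7-fold higher number (0.43 log units; beyond the scatter) from compound 1 to compound 2 and a 2.7-fold lower number (0.43 log units; beyond the scatter) from compound 4 to compound 3, 7.2-fold (0.86 log units) apart, beyond the scatter of two such steps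

The compounds shown leave open whether the hydroxy is specifically needed on the benzyl amide, or whether an amine or a methoxy at the same place would serve as well. They also leave open whether a longer chain between the amide nitrogen and the ring would follow the benzyl amides or depart from them.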